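The source may report more compounds than this note shows. Statements on the series, on what has been measured and on what is new or still open speak of the compounds shown alone.

Measured compounds:
compound 1, `Cc1nc(SCC(=O)Nc2nc(-c3ccc(Cl)cc3)cs2)n(Nc2ccccc2)c1C`, with 3010 nM
compound 2, `Cc1ccc(Nn2c(SCC(=O)Nc3nc(-c4ccccc4)cs3)nc(C)c2C)cc1`, with 3340 nM

In a functional assay on MDA-MB-231 cells (Homo sapiens) for antiproliferative activity, read by sulforhodamine B assay, with a stated time of 48 h (a higher number here means a weaker inhibitor of growth, a lower number a stronger inhibitor of growth), compound 1 gives 3010 nM and compound 2 gives 3340 nM; the two numbers sit within the scatter of each other, so neither compound can be ranked above the other. Compound 3, `COc1ccc(Nn2c(SCC(=O)Nc3nc(-c4ccc(Cl)cc4)cs3)nc(C)c2C)cc1`, differs from compound 1 by methoxy in place of hydrogen on an aromatic carbon. Within the data shown here, no measured pair shows this change, so no step beyond the scatter is expected in this assay. The step from compound 1 to compound 3 is expected to be a 1.0-fold lower number from compound 1 to compound 3 (0.00 log units; within the scatter). Compound 3 is estimated at 3000 nM, between 1200 nM and 7500 nM.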

Compound 3, concentration for 50% growth inhibition: 8370 nM
The estimate for compound 3 lay 2.8-fold (0.45 log units) below the measured number, outside the stated range (above it).
By their numbers in this assay, from the lowest: compounds 1 and 2 (each within the scatter of the next); then compound 3.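

In this assay, methoxy in place of hydrogen on an aromatic carbon, para to a large group, gives a 2.8-fold higher number from compound 1 to compound 3 (0.44 log units; beyond the scatter), so growth inhibition at this position responds to this change, and it weakens. Compound 1 and compound 2 could not show this, as they differ in more than one place. Nothing at hand explains the step. The compounds shown leave open whether a methyl group, a fluorine atom or an amine at this position would act as methoxy does, and whether methoxy would have the same effect on compound 2.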